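The source may report more compounds than this note shows. Statements on the series, on what has been measured and on what is new or still open speak of the compounds shown alone.

Measured so far in a functional assay on HeLa cells (Homo sapiens) for cytotoxicity, read by MTT assay, with a stated time of 48 h; on this read-out higher numbers stand for weaker inhibition and lower numbers for stronger inhibition:
- compound 1 `Cc1nc2c3ccccc3ccc2c2nc3c(ccc4ccccc43)c(-c3cc([N+](=O)[O-])ccc3N)c12` — 5770 nM
- compound 2 `Cc1nc2c3ccccc3ccc2c2nc3c(ccc4ccccc43)c(-c3ccc(O)cc3)c12` — 4630 nM

Among the compounds with values here, compound 1 sits at the top of these two numbers, but its only neighbour, compound 2, lies within the scatter of it: the step of a 1.2-fold lower number from compound 1 to compound 2 (0.10 log units; within the scatter) does not separate the pair. The two compounds share the same core and differ only in the aryl group hanging from it.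

Compound 3 `Cc1ccc(-c2c3ccc4ccccc4c3nc3c2c(C)nc2c4ccccc4ccc32)cc1` keeps that core and changes the same position: 4-methylphenyl in place of 2-amino-5-nitrophenyl on an aromatic carbon. Within the data shown here, the one measured step that bears on this is the exchange at the same aromatic carbon from compound 1 to compound 2, which swapped the 2-amino-5-nitrophenyl for 4-hydroxyphenyl and moved the number only within the scatter. Among the measured compounds shown here, a second swap at that carbon, this time to a group with no hydrogen-bond donors or acceptors, has no measured precedent of its own; the nearest evidence points to little movement in this assay.

For compound 3 the expectation is therefore a number close to that of compound 1, with the step of a 1.2-fold lower number from compound 1 to compound 3 (0.06 log units; within the scatter) estimated to stay within the scatter. Compound 3 is estimated at 5000 nM, with a range from 2200 nM to 11000 nM.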

Compound 3, half-maximal inhibitory concentration: 72200 nM
Estimate against measurement, compound 3: 14-fold (1.16 log units) below; measured number above the stated range.
By their numbers in this assay, from the lowest: compounds 2 and 1 (each within the scatter of the next); then compound 3.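

In this assay, the aromatic carbon opposite the ring nitrogen turns out not to be indifferent to its aryl group, as the earlier exchange there had suggested: 4-methylphenyl in place of 2-amino-5-nitrophenyl gives a 13-fold higher number from compound 1 to compound 3 (1.10 log units; beyond the scatter). The smallest edit in the series has an equally large outcome, since methyl in place of hydroxy gives a 16-fold higher number from compound 2 to compound 3 (1.19 log units; beyond the scatter), so a single substituent on the 4-substituted phenyl ring is enough to weaken inhibition clearly, while two quite different aryl groups had stayed within the scatter of each other. Among these three compounds, the only group made of carbon alone gives the weak number, but nothing available accounts for this.

Still open, on these data alone, is whether the step follows from the methyl itself or from the absence of a hydroxy, amino or nitro substituent on the ring, and an unsubstituted phenyl, a 4-aminophenyl or a 4-methoxyphenyl at this carbon would bear on that question. Also open, as far as these compounds go, is how a carboxylic acid or a longer alkyl chain on the same ring would read in this assay.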